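A Third Aromatic Group on the Shared Core

A few compounds are considered here, and "the series" means these few. Any claim that something is new, unique, unknown or untested is made for them only; others in the source may bear on it.

Measured so far in a functional assay on A549 cells (Homo sapiens) for cytotoxicity, read by MTT assay, with a stated time of 72 h; on this read-out higher numbers stand for weaker inhibition and lower numbers for stronger inhibition:
compound 1 `CN(C)CCn1cnnc1-c1cc(Oc2ccc(NC(=O)N/N=C/c3c[nH]c4ccccc34)cc2F)ccn1`: 820 nM
compound 2 `COc1ccc(OC)c(/C=N/NC(=O)Nc2ccc(Oc3ccnc(-c4nncn4CCN(C)C)c3)c(F)c2)c1`: 1950 nM

For the measured compounds named here, compound 2 gives the higher of the two numbers, so it inhibits the cells less strongly than compound 1; the only measured step, a 2.4-fold higher number from compound 1 to compound 2 (0.38 log units; beyond the scatter), lies beyond the scatter. Compound 3 `CN(C)CCn1cnnc1-c1cc(Oc2ccc(NC(=O)N/N=C/c3ccc(O)c(Br)c3)cc2F)ccn1` has not yet been measured. It differs from compound 2 in one place: 3-bromo-4-hydroxyphenyl in place of 2,5-dimethoxyphenyl on a carbon with a double bond to nitrogen. Going by the values given here, no measured step covers this particular exchange; the one known step shows only that swapping the group on this carbon can shift the number modestly, and it gives no direction for a group carrying one hydrogen-bond donor. A small improvement at most is therefore expected, a 1.6-fold lower number from compound 2 to compound 3 (0.21 log units; within the scatter). Compound 3 is estimated at 1200 nM, with a range from 400 nM to 3600 nM.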

Compound 3, half-maximal inhibitory concentration: 1370 nM
For compound 3 the middle estimate is 1.1-fold (0.06 log units) below the measured one; low and high end bracket the measured number.
By their numbers in this assay, from the lowest: compounds 1, 3 and 2 (each within the scatter of the next, the first and the last beyond it).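

In this assay, the exchange of groups gives a 1.4-fold lower number from compound 2 to compound 3 (0.15 log units; within the scatter), while the exchange from the indole gives a 1.7-fold higher number from compound 1 to compound 3 (0.22 log units; within the scatter). This position therefore accepts 3-bromo-4-hydroxyphenyl, a group with a hydrogen-bond donor and a bromine, and its number cannot be told apart from that of either earlier compound, even though those two differ beyond the scatter. No separate measurement bears on what lies behind these numbers.

Going by these compounds, the hydroxyl and the bromine enter together here, so the share of each remains open, and a plain 4-hydroxyphenyl or 3-bromophenyl would separate them. Also open, on these data alone, is how the number responds when this carbon carries something other than an aromatic ring, such as a carboxylic acid or a short chain ending in an amine.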